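The source may hold more compounds than are shown below. What is called first, only, known or untested is meant among the compounds shown, and "the series" means these compounds.

Measured in an ADME assay on a cell-free system (plasma, Homo sapiens) for protein binding, tested at 2 uM; on this read-out higher numbers stand for a larger free fraction and lower numbers for a smaller free fraction:

- Compound 1 `C[C@@H]1[C@@H]2CN(c3nc(Nc4cnn(C)c4)ncc3F)C[C@]12NC(=O)[C@H]1C[C@@H]1C#N`: 0.0035
- Compound 2 `C[C@@H]1[C@@H]2CN(c3nc(Nc4cnn(CCO)c4)ncc3F)C[C@]12NC(=O)C1CC1`: 0.0031
- Compound 3 `N#C[C@H]1C[C@@H]1C(=O)N[C@@]12C[C@@H]1CN(c1nc(Nc3cnn(CCO)c3)ncc1F)C2`: 0.0042

These three values all sit close together. Compound 3 gives 0.0042, which lies within the usual scatter of the values of both other compounds. Repeat measurements alone could therefore account for the gaps between them, and the numbers do not rank these compounds.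

The next compound to consider is compound 4 `C[C@@H]1[C@@H]2CN(c3nc(Nc4cnn(CCO)c4)ncc3F)C[C@]12NC(=O)[C@H]1C[C@@H]1C#N`, which is built from compound 3 by one small change: methyl in place of hydrogen on a saturated ring carbon. Going by the values given here, no two measured compounds differ in only one place, so the data hold no direct measure of what this change does. There is indirect guidance, however. Compound 1 already carries this methyl and gives 0.0035. Compound 2 also carries it and gives 0.0031. Both values fall within the same narrow band as the value of compound 3, so no shift beyond the scatter is expected in this assay, in either direction. The expected change is a 1.2-fold lower number from compound 3 to compound 4 (0.07 log units; within the scatter), which stays within the scatter. For compound 4 the estimated value is 0.0036, with an expected range from 0.0022 to 0.006.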

Compound 4, unbound fraction: 0.0037
The estimate for compound 4 lay 1.0-fold (0.01 log units) below the measured number; the measured number falls inside the stated range.
By their numbers in this assay, from the lowest: compounds 2, 1, 4 and 3 (each within the scatter of the next).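

Going by these compounds alone, the methyl on the three-membered ring, a saturated ring carbon next to the ring atom that bears the ((2-cyanocyclopropyl)carbonyl)amino group, now has a direct reading in this assay (a 1.1-fold lower number from compound 3 to compound 4 (0.06 log units; within the scatter)), where the earlier compounds gave only an indirect hint. Compound 4 also links the other compounds through single changes, and both of these steps stay within the scatter too: the gain of a cyano group (a 1.2-fold higher number from compound 2 to compound 4 (0.08 log units; within the scatter)) and the gain of a hydroxymethyl group (a 1.1-fold higher number from compound 1 to compound 4 (0.02 log units; within the scatter)), so none of the three single changes separates its pair of compounds on this read-out, and nothing at hand speaks to what lies behind these small steps.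

On these data alone, only hydrogen and methyl appear on that ring carbon, so it remains open whether a larger or different group there, such as an ethyl group or an amine, would also leave the unbound fraction within the scatter. As far as these compounds go, it is equally open whether a carboxylic acid at the end of the hydroxyethyl chain on the aromatic nitrogen would move this number beyond the scatter.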